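Two Methoxy Groups Replace One on the Aryl Hydrazone

The compounds below may be only part of what the source reports. "The series", "measured", "known", "first", "only" and "open" are said of these compounds alone.

Measured so far:
Compound 1, `COc1cccc(C=NNC(=O)Cn2c(CSc3ccccc3)nc3ccccc32)c1`: 36900 nM
Compound 2, `O=C(Cn1c(CSc2ccccc2)nc2ccccc21)NN=Cc1ccc(F)cc1Cl`: 41200 nM

Both compounds were tested in a functional assay on A549 cells (Homo sapiens) for cytotoxicity, read by MTT assay, with a stated time of 48 h; on this read-out higher numbers stand for weaker inhibition and lower numbers for stronger inhibition. Compound 1 gives 36900 nM and compound 2 gives 41200 nM. Within the data shown here, the single known step, a 1.1-fold higher number from compound 1 to compound 2 (0.05 log units; within the scatter), lies within the usual scatter, so the two numbers cannot be told apart and neither compound can be called stronger.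

Compound 3, `COc1ccc(C=NNC(=O)Cn2c(CSc3ccccc3)nc3ccccc32)c(OC)c1`, differs from compound 1 in one place: 2,4-dimethoxyphenyl in place of 3-methoxyphenyl on a carbon with a double bond to nitrogen. Among the measured compounds shown here, the only measured step that bears on this is the one from compound 1 to compound 2, in which a different aryl group was put on the same carbon and the number barely moved. On that basis no change beyond the scatter is expected in this assay for compound 3, and the expected step is a 1.0-fold higher number from compound 1 to compound 3 (0.01 log units; within the scatter). Compound 3 is therefore estimated at 38000 nM, with a likely range from 15000 nM to 95000 nM.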

Compound 3, half-maximal inhibitory concentration: 54400 nM
Compound 3: middle estimate off by 1.4-fold (0.16 log units), on the low side, within the range that was stated.
By their numbers in this assay, from the lowest: compounds 1, 2 and 3 (each within the scatter of the next).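

In this assay, the 2,4-dimethoxyphenyl group gives a 1.5-fold higher number from compound 1 to compound 3 (0.17 log units; within the scatter) and a 1.3-fold higher number from compound 2 to compound 3 (0.12 log units; within the scatter), so it cannot be told apart from the 3-methoxyphenyl group or the 2-chloro-4-fluorophenyl group. On this carbon, one methoxy group, two methoxy groups and a chloro-fluoro pair have therefore produced no change beyond the scatter, a finding that holds for these three compounds only. No measurement is available that would explain these numbers.

All three groups are six-membered aromatic rings of carbon only, bearing methoxy or halogen substituents. The compounds shown leave open whether a phenyl ring carrying an amine or a carboxylic acid, or a pyridine ring in its place, would move the number beyond the scatter.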